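Swapping Nitro for Chloro in Compound 3

The source may report more compounds than this note shows. Statements on the series, on what has been measured and on what is new or still open speak of the compounds shown alone.

Compound 3 `CC(C)N(CCN(C(=O)Nc1cccc([N+](=O)[O-])c1)C1CC[C@]2(c3cccc(C#N)c3)CC2C1)C(C)C` gives 2.7 nM in a functional assay for antagonist activity at melanin-concentrating hormone receptor 1 (Homo sapiens) (a lower number here means a stronger inhibitor, a higher number a weaker inhibitor), the lowest of the three numbers measured. Compound 1 `N#Cc1cccc([C@]23CCC(N(CCN4CC[C@@H](O)C4)C(=O)Nc4ccccc4)CC2C3)c1` gives 132 nM and compound 2 `N#Cc1cccc([C@]23CCC(N(CCN4CC[C@@H](O)C4)C(=O)Nc4cccc([N+](=O)[O-])c4)CC2C3)c1` gives 60 nM. Across those compounds, a 2.2-fold lower number from compound 1 to compound 2 (0.34 log units; beyond the scatter) for nitro in place of hydrogen on an aromatic carbon, and a 22-fold lower number from compound 2 to compound 3 (1.35 log units; beyond the scatter) for the change at the saturated chain carbon. Compound 4 `CC(C)N(CCN(C(=O)Nc1cccc(Cl)c1)C1CC[C@]2(c3cccc(C#N)c3)CC2C1)C(C)C` differs from compound 3 by chloro in place of nitro on an aromatic carbon. For the measured compounds named here, only the first of those steps bears on this position, and it was modest; no measured step compares chloro with nitro. A modest move toward a higher number, or none beyond the scatter, is therefore expected. Compound 4 is expected to give 5 nM, in the range 1.5 nM to 16 nM. The expected step is a 1.9-fold higher number from compound 3 to compound 4 (0.27 log units; within the scatter).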

Compound 4, inhibition constant: 6 nM
The estimate for compound 4 lay 1.2-fold (0.08 log units) below the measured number; measured number inside the range.
By their numbers in this assay, from the lowest: compound 3; then compound 4; then compound 2; then compound 1.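

In this assay, the nitro group proves not to be essential at this aromatic carbon: chloro, a single heavy atom with no hydrogen-bond acceptors, costs only a 2.2-fold higher number from compound 3 to compound 4 (0.35 log units; beyond the scatter). That modest step is beyond the scatter, so nitro still keeps the lower number in the diisopropylamino series. Nothing available explains this difference between nitro and chloro. The compounds shown leave open how hydrogen would compare with chloro or nitro in this series. They also do not show whether fluoro, methoxy or an amine at this place would give a lower or higher number.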